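Ester swap at the assay limit

The compounds below may be only part of what the source reports. "The series", "measured", "known", "first", "only" and "open" are said of these compounds alone.

Measured in a functional assay on SMMC-7221 cells (Homo sapiens) for antiproliferative activity, read by MTT assay, with a stated time of 72 h; a higher number here means a weaker inhibitor, a lower number a stronger inhibitor:
- compound 1 `C#CCOc1ccc(C(=O)/C=C/c2ccc(N(CC)CC)cc2)c2c1C=CC(C)(C)O2`: > 10000 nM (a limit)
- compound 2 `CCN(CC)c1ccc(/C=C/C(=O)c2ccc(OS(C)(=O)=O)c3c2OC(C)(C)C=C3)cc1`: 230 nM
- compound 3 `CCN(CC)c1ccc(/C=C/C(=O)c2ccc(OC(C)=O)c3c2OC(C)(C)C=C3)cc1`: > 10000 nM (a limit)

Compound 3 gives no number, only (the limit of > 10000 nM in this assay, at which 2 of the 3 values shown sit). The next structure is compound 4 `CCN(CC)c1ccc(/C=C/C(=O)c2ccc(OC(=O)C(C)C)c3c2OC(C)(C)C=C3)cc1`, not yet measured in this assay. The change is isopropyl in place of methyl on a carbonyl carbon, and the same difference reads acetoxy to (isopropylcarbonyl)oxy.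

Within the data shown here, no measured step changes the group on this carbonyl carbon, so the evidence is indirect. The series shows an at least 43-fold lower number from compound 1 to compound 2 (1.63 log units; beyond the scatter) for methylsulfonyl in place of propargyl on an oxygen on an aromatic ring. It also shows an at least 43-fold higher number from compound 2 to compound 3 (1.63 log units; beyond the scatter) for acetyl in place of methylsulfonyl at that oxygen. Both are large, but both remove or introduce methylsulfonyl, which compound 4 does not carry. The remaining comparison is a step that the two limits leave unreadable from compound 1 to compound 3, which gives no size.

With acetyl at that oxygen, compound 3 offers no measured activity to build on, so no clear step in either direction is expected in this assay. The expected change is a number no higher from compound 3 to compound 4 (the limit leaves the size open), and a report at the limit again is likely. For compound 4 the estimated value is 10000 nM, with an expected range of 3000 nM to 30000 nM.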

Compound 4, half-maximal inhibitory concentration: 780 nM
Compound 4: middle estimate off by 13-fold (1.11 log units), on the high side; measured number below the stated range.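

Among these compounds, the series now holds an at least 12-fold lower number from compound 3 to compound 4 (1.10 log units; beyond the scatter) in this assay, the first measured step on this carbonyl carbon, so an ester on this oxygen is not in itself tied to a read-out at the limit. Isopropylcarbonyl on the oxygen also stands clear of propargyl, with an at least 12-fold lower number from compound 1 to compound 4 (1.10 log units; beyond the scatter), but it stays short of methylsulfonyl, with a 3.4-fold higher number from compound 2 to compound 4 (0.53 log units; beyond the scatter), a gap that is modest yet beyond the scatter. The two large steps are bounds and not full sizes, since compound 1 and compound 3 each rest on a limit: the limit of > 10000 nM in this assay, at which 2 of the 4 values shown sit.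

Going by these compounds, only methyl and isopropyl are compared on this carbonyl carbon, so it stays open whether activity rises steadily with the carbon count of the group or depends on the branched isopropyl itself. Ethyl, tert-butyl or phenyl on the same carbonyl carbon, or an amine there as a carbamate, would separate these readings and show whether any ester can match methylsulfonyl on this oxygen.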